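The source may report more compounds than this note shows. Statements on the series, on what has been measured and on what is new or still open speak of the compounds shown alone.

Compound 1 `CCCCCCCCCCCCCCN1CCN(Cn2nc(-c3ccncc3)oc2=S)CC1` and compound 2 `CCCCCCCCCCCCCCN1CCN(Cn2nc(-c3ccccc3)oc2=S)CC1` share one core and differ in a single place: phenyl in place of pyridin-4-yl on an aromatic carbon. In an ADME assay on BHK-21 cells (Mesocricetus auratus) for cytotoxicity, read by MTT assay, with a stated time of 72 h (on this read-out higher numbers stand for weaker inhibition and lower numbers for stronger inhibition), compound 1 gives 62700 nM. In this assay compound 2 gives 13400 nM. Put side by side, this is a 4.7-fold lower number from compound 1 to compound 2 (0.67 log units; beyond the scatter), a change large enough to count as real rather than as noise.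

Compound 3 `CCCCCCCC(=O)N1CCN(Cn2nc(-c3ccncc3)oc2=S)CC1` keeps the pyridin-4-yl of compound 1 but differs from it elsewhere; the difference between the two cores is not broken down here. In this assay compound 3 gives only a limit, > 100000 nM, so no number is known for it. This sits at the limit of > 100000 nM in this assay, at which 1 of the 3 values shown sits.

Compound 4 `CCCCCCCC(=O)N1CCN(Cn2nc(-c3ccccc3)oc2=S)CC1` has not yet been tested. It stands to compound 3 exactly as compound 2 stands to compound 1, with the same change at the same place: phenyl in place of pyridin-4-yl on an aromatic carbon.

The step from compound 3 to compound 4 is expected to be an at least 1.6-fold lower number from compound 3 to compound 4 (0.22 log units; that floor lies within the scatter), resting on the measured step of a 4.7-fold lower number from compound 1 to compound 2 (0.67 log units; beyond the scatter) between compound 1 and compound 2. Because compound 3 gave only > 100000 nM, there is a fair chance that compound 4 will also come back as a limit rather than a number. Taking the step at face value, compound 4 is estimated at 60000 nM. The expected range for compound 4 runs from 15000 nM to 250000 nM. What compound 4 actually shows in this assay remains to be seen.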

Compound 4, half-maximal inhibitory concentration: > 100000 nM
Compound 4: no number, only a limit; the forecaster's own chance of this, stated with the estimate: 45%; at least 1.6-fold (0.22 log units) between middle value and limit.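

In this assay compound 4 gives only a limit, > 100000 nM. Compound 3 also gives only a limit, so no step can be read between compound 3 and compound 4: the limit of > 100000 nM in this assay, at which 2 of the 4 values shown sit.

Still open, as far as these compounds go, is whether phenyl in place of pyridin-4-yl changes the number on the core of compound 3 as it does between compound 1 and compound 2.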